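The compounds below may be only part of what the source reports. "The series", "measured", "known", "first", "only" and "open" are said of these compounds alone.

Working notes on the series.

Compound 1 `CC(C)=CCOc1cc(Nc2ncnc(Cl)n2)ccc1Cl` gives 45000 nM in an ADME assay on MT2 cells (Homo sapiens) for cytotoxicity; on this read-out lower numbers stand for higher toxicity in this test and higher numbers for lower toxicity in this test. Compound 2 `CC(C)=CCOc1cc(Nc2nc(C)nc(Cl)n2)ccc1Cl` gives 40000 nM in this assay; the step of a 1.1-fold lower number from compound 1 to compound 2 (0.05 log units; within the scatter) comes from the change (methyl in place of hydrogen on an aromatic carbon). Compound 3 `CC(C)=CCOc1cc(Nc2ncccn2)ccc1Cl` gives 2500 nM in this assay, the lowest of the three numbers; the step of an 18-fold lower number from compound 1 to compound 3 (1.26 log units; beyond the scatter) comes from the change (pyrimidin-2-yl in place of 4-chloro-1,3,5-triazin-2-yl on a nitrogen on an aromatic ring), which tells how the core of compound 3 differs from that of compound 1.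

Compound 4 `CC(C)=CCOc1cc(Nc2nccc(C)n2)ccc1Cl` is not yet measured in this assay. It differs from compound 3 by methyl in place of hydrogen on an aromatic carbon. This is the same kind of change as from compound 1 to compound 2, but the surroundings differ: in compound 2 the methyl sits between two ring nitrogen atoms and meta to a chloro group, whereas in compound 4 it sits next to the ring nitrogen. The step from compound 1 to compound 2 was within the scatter, so a comparable step is expected for compound 4, namely no change at the digits printed from compound 3 to compound 4 (within the scatter), because the value of compound 3 2500 nM serves as the base. Compound 4 is therefore estimated at 2500 nM, within 1000 nM to 6000 nM.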

Compound 4, half-maximal cytotoxic concentration: 150 nM
The estimate for compound 4 lay 17-fold (1.22 log units) above the measured number; the measured number lies below the stated range.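

In this assay, methyl in place of hydrogen on an aromatic carbon does not carry over from one core to the other: the same change on two cores in this assay, a 1.1-fold lower number (0.05 log units; within the scatter) from compound 1 to compound 2 and a 17-fold lower number (1.22 log units; beyond the scatter) from compound 3 to compound 4, 15-fold (1.17 log units) apart, beyond the scatter of two such steps

On the pyrimidin-2-yl core the change gives a large step (a 17-fold lower number from compound 3 to compound 4 (1.22 log units; beyond the scatter)), and replacing 4-chloro-1,3,5-triazin-2-yl with 4-methylpyrimidin-2-yl gives a larger one (a 300-fold lower number from compound 1 to compound 4 (2.48 log units; beyond the scatter)). These two pairs show that the size of the methyl step depends on the core, but not which feature of the core sets it or what the change would do on a further core.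

As far as these compounds go, it remains open whether ethyl or an amine on the same aromatic carbon would follow methyl. From the compounds shown here alone, it also remains open whether the lower numbers persist when the chloro group on the 4-methylpyrimidin-2-yl core's outer ring is replaced by a methoxy group.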